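The source may report more compounds than this note shows. Statements on the series, on what has been measured and on what is new or still open speak of the compounds shown alone.

Of the compounds shown here, three with a shared core have been tested so far. In a functional assay on MIA PaCa-2 cells (Homo sapiens) for inhibition, read by MTT assay, with a stated time of 7 days (a lower number here means a stronger inhibitor, a higher number a weaker inhibitor), compound 1 `CCN(CC)C(=O)[C@@H]1CCCN(S(=O)(=O)c2ccc(S(=O)(=O)N(CC)CC)cc2)C1` gives 6400 nM, compound 2 `CCN(CC)S(=O)(=O)c1ccc(S(=O)(=O)N2CCC[C@@H](C(=O)NC)C2)cc1` gives 8600 nM, and compound 3 `CCN(CC)S(=O)(=O)c1ccc(S(=O)(=O)N2CCC[C@@H](C(=O)N3CCN(c4nc(C)no4)CC3)C2)cc1` gives 250 nM. Compound 3 stands lowest of the three: the step of a 26-fold lower number from compound 1 to compound 3 (1.41 log units; beyond the scatter) and the step of a 34-fold lower number from compound 2 to compound 3 (1.54 log units; beyond the scatter) both lie beyond the scatter, whereas the step of a 1.3-fold higher number from compound 1 to compound 2 (0.13 log units; within the scatter) does not. Compound 4 `CCN(CC)S(=O)(=O)c1ccc(S(=O)(=O)N2CCC[C@@H](C(=O)NC3CN(S(C)(=O)=O)C3)C2)cc1` awaits measurement in this assay. It differs from compound 3 in one place: (1-(methylsulfonyl)azetidin-3-yl)amino in place of 4-(3-methyl-1,2,4-oxadiazol-5-yl)piperazin-1-yl on a carbonyl carbon. The two steps that bear on this position show that the 4-(3-methyl-1,2,4-oxadiazol-5-yl)piperazin-1-yl group accounts for the whole gap between compound 3 and the smaller amides of compound 1 and compound 2. Since compound 4 carries neither that group nor one of those small amides, the expected step of a 10-fold higher number from compound 3 to compound 4 (1.00 log units; beyond the scatter) points back toward higher numbers, though not all the way. Compound 4 is therefore estimated at 2500 nM, with a range from 800 nM to 8000 nM.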

Compound 4, half-maximal inhibitory concentration: 2500 nM
For compound 4 middle estimate and measured number coincide at the digits printed, within the range that was stated.
By their numbers in this assay, from the lowest: compound 3; then compound 4; then compounds 1 and 2 (each within the scatter of the next).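

In this assay, the position on the carbonyl carbon proves to allow more than one level of improvement: a 3.4-fold lower number from compound 2 to compound 4 (0.54 log units; beyond the scatter) and a 2.6-fold lower number from compound 1 to compound 4 (0.41 log units; beyond the scatter) both lie beyond the scatter, so a group other than 4-(3-methyl-1,2,4-oxadiazol-5-yl)piperazin-1-yl can also lower the number. Even so, a 10-fold higher number from compound 3 to compound 4 (1.00 log units; beyond the scatter) leaves compound 3 alone at the low end, so (1-(methylsulfonyl)azetidin-3-yl)amino closes only part of the gap left by the small amides. Nothing measured here accounts for either difference.

The compounds shown do not separate the contribution of the amide hydrogen in compound 4 from that of its azetidine ring or methylsulfonyl group. They also leave open whether the piperazine or the oxadiazole drives the low number of compound 3, which a piperazine bearing an acetyl group at this place could help to test.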